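This account rests on a few compounds, and the source may have more. Where it says the series, first, only, none or still open, it means among the compounds named here.

Measured so far in an ADME assay on K562 cells (Homo sapiens) for cytotoxicity, with a stated time of 72 h; on this read-out lower numbers stand for stronger inhibition and higher numbers for weaker inhibition:
Compound 1 `Oc1ccccc1CNc1ncnc2c1ncn2C1CCCCO1`: > 100000 nM
Compound 2 `Oc1cccc(CNc2ncnc3c2ncn3C2CCCCO2)c1`: 81000 nM

The entry for compound 1, > 100000 nM, is a limit of the assay and not a number. Among the measured compounds shown here, compound 2, at 81000 nM, holds the only true number in this assay so far.

Compound 3 `Oc1ccc(CNc2ncnc3c2ncn3C2CCCCO2)cc1` has not yet been measured. It keeps the shared core and differs from compound 2 thus: 4-hydroxyphenyl in place of 3-hydroxyphenyl on a saturated chain carbon bound to a nitrogen on an aromatic ring. In words, 4-hydroxyphenyl stands in place of 3-hydroxyphenyl on a saturated chain carbon bound to a nitrogen on an aromatic ring.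

For the measured compounds named here, one measured step bears on this change: an at least 1.2-fold lower number from compound 1 to compound 2 (0.09 log units; that floor lies within the scatter), which swapped 2-hydroxyphenyl for 3-hydroxyphenyl at the same place. It offers no direction, so nothing beyond the scatter is expected here. The expected step is a 1.0-fold lower number from compound 2 to compound 3 (0.01 log units; within the scatter). For compound 3 the estimated value is 80000 nM, with an expected range from 35000 nM to 150000 nM.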

Compound 3, half-maximal inhibitory concentration: > 100000 nM
Compound 3 gave a limit, no number; the forecaster's own chance of this, stated with the estimate: 35%; middle value at least 1.2-fold (0.09 log units) away from the limit.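

With 4-hydroxyphenyl on the saturated chain carbon bound to a nitrogen on an aromatic ring, as with 2-hydroxyphenyl, this assay returns a limit of the assay and not a number: the limit of > 100000 nM in this assay, at which 2 of the 3 values shown sit. The change from 3-hydroxyphenyl to 4-hydroxyphenyl gives an at least 1.2-fold higher number from compound 2 to compound 3 (0.09 log units; that floor lies within the scatter), so, like the earlier step at this place, it shows no difference beyond the scatter. The step that joins the two limits cannot be read, and the three hydroxyphenyl compounds therefore cannot be put in any order.

As far as these compounds go, how far the true values of compound 1 and compound 3 lie from the limit remains open. Also open, from the compounds shown here alone, is whether an amine or a carboxylic acid in place of the hydroxyl group, or a longer chain in place of the saturated chain carbon, would give a clearly lower number.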